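The compounds below may be only part of what the source reports. "The series", "measured", "known", "first", "only" and "open" are said of these compounds alone.

Measured compounds:
Compound 1, `O=C(/C=C\Nc1ccc(C(F)(F)F)cc1)c1cn(-c2ccccc2)nc1-c1ccc(F)cc1`, in an ADME assay on HaCaT cells (Homo sapiens) for antiproliferative activity, read by MTT assay, with a stated time of 48 h (on this read-out higher numbers stand for weaker inhibition and lower numbers for stronger inhibition), gives > 50000 nM; this is a limit of the assay, not a number.
Compound 2, `O=C(/C=C\Nc1ccc(O)cc1)c1cn(-c2ccccc2)nc1-c1ccc(F)cc1`, in this assay gives 16300 nM.
Compound 3, `O=C(/C=C\Nc1ccc(C(F)(F)F)cc1)c1cn(-c2ccccc2)nc1-c1ccc(Cl)cc1`, in this assay gives > 50000 nM; this too is a limit of the assay.

Compound 2 differs from compound 1 in one spot: hydroxy in place of trifluoromethyl on an aromatic carbon. In this assay this change made an at least 3.0-fold lower number from compound 1 to compound 2 (0.48 log units; beyond the scatter).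

Compound 3 differs from compound 1 only in its core, and the difference is chloro in place of fluoro on an aromatic carbon. The step that the two limits leave unreadable from compound 1 to compound 3 cannot be sized because of the limit of > 50000 nM in this assay, at which 2 of the 3 values shown sit.

Compound 4, `O=C(/C=C\Nc1ccc(O)cc1)c1cn(-c2ccccc2)nc1-c1ccc(Cl)cc1`, is still unmeasured. It differs from compound 3 by hydroxy in place of trifluoromethyl on an aromatic carbon. The surroundings of the change read the same, word for word, as for the change from compound 1 to compound 2, so this is the same change, now made on the core of compound 3.

In this assay the expected step is an at least 2.5-fold lower number from compound 3 to compound 4 (0.39 log units; beyond the scatter), set beside the earlier at least 3.0-fold lower number from compound 1 to compound 2 (0.48 log units; beyond the scatter). That expectation rests on a single measured pair, and since compound 3 sits at a limit, the true size of the step from it is not readable; a second limit for compound 4 is also a real possibility.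

For compound 4 in this assay the estimated value is 20000 nM, expected to lie between 8000 nM and 50000 nM, guided by the number that compound 2 gave, 16300 nM.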

Compound 4, half-maximal inhibitory concentration: 22600 nM
For compound 4 the middle estimate is 1.1-fold (0.05 log units) below the measured one, and the stated range covers the measured number.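

In this assay, where a lower number means stronger inhibition, putting hydroxy in place of trifluoromethyl worked in the same direction on the second core, giving an at least 2.2-fold lower number from compound 3 to compound 4 (0.34 log units; beyond the scatter), so the direction of this change carried over on both cores shown. Between the two hydroxy compounds, chloro in place of fluoro gives a 1.4-fold higher number from compound 2 to compound 4 (0.14 log units; within the scatter), which leaves these two values within the usual scatter of each other, while the matching step between the two trifluoromethyl compounds cannot be read: the limit of > 50000 nM in this assay, at which 2 of the 4 values shown sit. What the pairs do not show is that the change keeps the same size from one core to the other, since each step is a minimum and not a measured size: the same change on two cores in this assay, an at least 3.0-fold lower number (0.48 log units; beyond the scatter) from compound 1 to compound 2 and an at least 2.2-fold lower number (0.34 log units; beyond the scatter) from compound 3 to compound 4; the limit leaves it open whether they differ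

As far as these compounds go, only trifluoromethyl and hydroxy are compared at this place on the ring, so it stays open how a methoxy group, an amine or a carboxylic acid there would read in this assay. From the compounds shown here alone, it also stays open whether the direction of the change would hold on a core carrying bromo or plain hydrogen in place of fluoro or chloro.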